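A few compounds are considered here, and "the series" means these few. Any claim that something is new, unique, unknown or untested is made for them only; others in the source may bear on it.

Compound 3, `C=CCCn1cnc2c1c(=O)n(C)c(=O)n2CCC`, is one of three measured xanthine-type compounds. In an assay on Cerebral cortex for binding affinity to adenosine receptor A1 (Cavia porcellus), read by radioligand binding (on this read-out higher numbers stand for weaker inhibition and lower numbers for stronger inhibition), compound 3 gives 6000 nM, the second highest number of the three. Compound 1, `C=CCCn1c(=O)c2[nH]cnc2n(CCC)c1=O`, gives 60 nM in this assay, and compound 2, `CCCn1c(=O)n(CCCOC)c(=O)c2[nH]cnc21`, gives 12400 nM. Compound 3 thus stands a little below compound 2 and well above compound 1.

The unmeasured compound 4 is `CCCn1c(=O)n(C)c(=O)c2c1ncn2CCN(C)C`. It differs from compound 3 by dimethylamino in place of vinyl on a saturated chain carbon, two bonds along the chain from an aromatic nitrogen. One measured step speaks to this kind of change: a 210-fold higher number from compound 1 to compound 2 (2.32 log units; beyond the scatter), where a group bearing a heteroatom replaced the vinyl at the same place on the chain. That step was large and went towards weaker inhibition. Among the compounds with values here, no step with a dimethylamino group itself has been measured, and compound 3 already lies far from compound 1, so the account rests on that single comparison.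

A weaker number is therefore expected for compound 4, with a step of roughly a 6.7-fold higher number from compound 3 to compound 4 (0.82 log units; beyond the scatter) in this assay, in the direction of weaker inhibition, though its size is uncertain because of the size of a 210-fold higher number from compound 1 to compound 2 (2.32 log units; beyond the scatter). The estimate for compound 4 in this assay is 40000 nM, within a range from 8000 nM to 200000 nM.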

Compound 4, inhibition constant: > 200000 nM
Compound 4: a limit, no number (the forecaster's own chance of this, stated with the estimate: 35%); at least 5.0-fold (0.69 log units) between middle value and limit.
By their numbers in this assay, from the lowest: compound 1; then compound 3; then compound 2. At a limit, above all of these: compound 4.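

In this assay, dimethylamino in place of vinyl on a saturated chain carbon, two bonds along the chain from an aromatic nitrogen, gives an at least 33-fold higher number from compound 3 to compound 4 (1.52 log units; beyond the scatter), a large step towards weaker inhibition. The earlier compounds shown here showed such a move away from vinyl at this place only for methoxymethyl, in a 210-fold higher number from compound 1 to compound 2 (2.32 log units; beyond the scatter), whereas the new step shows it with a nitrogen-bearing group and on a second parent, and neither of these two steps goes the other way. Compound 4 reads only as a limit and not as a number, so the step gives a lower bound and its full size stays unknown: the limit of > 200000 nM in this assay, at which 1 of the 4 values shown sits.

Going by these compounds, whether an ethyl group or a longer carbon chain at this place would keep the number close to that of the vinyl compounds remains open, as does whether a hydroxyl group or a primary amine would follow methoxymethyl and dimethylamino. Also open, on these data alone, is how a dimethylamino group at this place would read on the core of compound 1.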